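Notes on compound 4: propyl to isobutyl

This account rests on a few compounds, and the source may have more. Where it says the series, first, only, none or still open, it means among the compounds named here.

Measured so far:
- compound 1 `CCC1C(=O)N(C)c2cnc(Nc3ccc(S(=O)(=O)NCCO)cc3)nc2N1c1ccn(C)n1`: "not active" (no number reported)
- compound 2 `CCCCNS(=O)(=O)c1ccc(Nc2ncc3c(n2)N(c2ccn(C)n2)C(CC)C(=O)N3C)cc1`: 10600 nM
- compound 3 `CCCNC(=O)c1ccc2c(ccn2-c2ncc3c(n2)N(c2ccn(C)n2)C(CC)C(=O)N3C)c1`: "not active" (no number reported)

In a functional assay on A549 cells (Homo sapiens) for antiproliferative activity, read by CCK-8 assay, with a stated time of 72 h (on this read-out lower numbers stand for stronger inhibition of growth and higher numbers for weaker inhibition of growth), compound 3 has no single number and is recorded as "not active" (no number reported). Compound 1 is the only other entry of this kind, which leaves compound 2 as the sole numerical reference at 10600 nM.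

The next entry is compound 4 `CCC1C(=O)N(C)c2cnc(-n3ccc4cc(C(=O)NCC(C)C)ccc43)nc2N1c1ccn(C)n1`. The change is methyl in place of hydrogen on a saturated chain carbon bound to two saturated chain carbons, turning propyl into isobutyl.

Within the data shown here, no two measured compounds differ in one place only, so the data give no direct size for such a step. In this assay no step beyond the scatter is expected, and the likeliest result is another entry without a number. Should a number be reported, it is expected to lie near that of compound 2 at 10600 nM. Compound 4 is estimated at 15000 nM, with an expected range of 6000 nM to 40000 nM.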

Compound 4, concentration for 50% growth inhibition: 19200 nM
The estimate for compound 4 lay 1.3-fold (0.11 log units) below the measured number, within the range that was stated.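

In this assay compound 3 is recorded as "not active" (no number reported) and compound 4 gives 19200 nM so no step can be read between them. The compounds shown leave open how far propyl to isobutyl moves growth inhibition. Nothing available bears on a cause for this result.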